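This account rests on a few compounds, and the source may have more. Where it says the series, first, only, none or still open, it means among the compounds named here.

Compound 1 `COc1ccc(C(=O)NCc2ccc(CNS(=O)(=O)c3ccc(C)cc3)cc2)cc1`: 100 nM
Compound 2 `Cc1ccc(C(=O)NCc2ccc(CNS(=O)(=O)c3ccccc3)cc2)cc1`: 100 nM

Both compounds were tested in an assay on MDA-MB-231 cells for binding affinity to C-X-C chemokine receptor type 4 (Homo sapiens), read by immunofluorescence and microscopy, with stated times of 10 min and 30 min; on this read-out lower numbers stand for an effect already at smaller amounts and higher numbers for an effect only at larger amounts of compound. Compound 1 gives 100 nM there, and compound 2 gives 100 nM, so the two stand level at the digits shown, and the difference between their structures does not move the read-out beyond the usual scatter. Compound 3 `Cc1ccc(C(=O)NCc2ccc(CNS(=O)(=O)c3ccc(C)cc3)cc2)cc1` has not yet been measured. It differs from compound 2 in a single place: methyl in place of hydrogen on an aromatic carbon. The methyl enters on an aromatic carbon of a six-membered aromatic ring of carbon only. Compound 1 already carries the same methyl on that ring and gives 100 nM, level with compound 2, so no step beyond the scatter is expected in this assay, in neither direction. Compound 3 is therefore expected to give about 100 nM, with a range from 50 nM to 200 nM. This estimate means a step of no change at the digits printed from compound 2 to compound 3 (within the scatter), which is expected to stay within the scatter.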

Compound 3, effective concentration (reported as EC, without a stated level of effect): 1000 nM
Compound 3: the middle estimate sits 10-fold (1.00 log units) below what was measured; measured number outside the range, above it.
By their numbers in this assay, from the lowest: compounds 1 and 2 (each within the scatter of the next); then compound 3.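

In this assay, the change from phenyl to 4-methylphenyl gives a 10-fold higher number from compound 2 to compound 3 (1.00 log units; beyond the scatter), so even a single added methyl at this place, para to a large group, can shift the read-out well beyond the usual scatter. With the 4-methylphenyl kept, methyl in place of methoxy on an aromatic carbon gives a 10-fold higher number from compound 1 to compound 3 (1.00 log units; beyond the scatter), which shows that the outcome also depends on the group elsewhere in the molecule, and that neither place can be read on its own in these compounds. No measurement shown here gives a reason for either step.

The compounds shown leave open how a chlorine atom, an ethyl group or an amine would read at the position para to the large group. They also leave open whether a hydroxyl group could stand in place of the methoxy of compound 1 with the number unchanged.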